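The compounds below may be only part of what the source reports. "The series", "measured", "known", "first", "only" and "open" are said of these compounds alone.

Measured in a functional assay on DU-145 cells (Homo sapiens) for antiproliferative activity, read by WST assay, with a stated time of 3 days; on this read-out higher numbers stand for weaker inhibition and lower numbers for stronger inhibition:
- Compound 1 `CCCCCCCOc1c(-c2cc(OC)c(OC)c(OC)c2)oc2ccccc2c1=O`: > 50000 nM, a limit of the assay
- Compound 2 `CCCN(CCC)CCCCCOc1c(-c2cc(OC)c(OC)c(OC)c2)oc2ccccc2c1=O`: 24200 nM
- Compound 3 `CCCCCN(CCCCC)CCCCOc1c(-c2cc(OC)c(OC)c(OC)c2)oc2ccccc2c1=O`: 12500 nM

Compound 3 cannot be separated from compound 2, given a 1.9-fold lower number from compound 2 to compound 3 (0.29 log units; within the scatter). Both give a number, whereas compound 1 stands at a limit, as the limit of > 50000 nM in this assay, at which 1 of the 3 values shown sits, records. The steps away from that limit are an at least 2.0-fold lower number from compound 1 to compound 2 (0.31 log units; beyond the scatter) and an at least 4.0-fold lower number from compound 1 to compound 3 (0.60 log units; beyond the scatter).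

Compound 4 `CCCCCN(CCCCC)CCCCCOc1c(-c2cc(OC)c(OC)c(OC)c2)oc2ccccc2c1=O` has (dipentylamino)methyl in place of dipentylamino on a saturated chain carbon, four bonds along the chain from an oxygen on an aromatic ring. It keeps the dipentylamino group of compound 3 and shares the chain of compound 2. The closest guide is a 1.9-fold lower number from compound 2 to compound 3 (0.29 log units; within the scatter), which changes both features together and still stays within the scatter. The steps from compound 1 involve a much larger change and say little here. In this assay, the expected change is small, with no shift beyond the scatter, and the estimated step is a 1.1-fold lower number from compound 3 to compound 4 (0.06 log units; within the scatter).

For compound 4 the estimate is 11000 nM, with an expected range of 4500 nM to 25000 nM.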

Compound 4, half-maximal inhibitory concentration: 11700 nM
Compound 4: the middle estimate sits 1.1-fold (0.03 log units) below what was measured, within the range that was stated.
By their numbers in this assay, from the lowest: compounds 4, 3 and 2 (each within the scatter of the next, the first and the last beyond it). At a limit, above all of these: compound 1.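

In this assay, with the dipentylamino group held in place, the longer chain does not separate the pair: a 1.1-fold lower number from compound 3 to compound 4 (0.03 log units; within the scatter). With the chain length held instead, dipentylamino in place of dipropylamino gives a modest step that lies just beyond the scatter, a 2.1-fold lower number from compound 2 to compound 4 (0.32 log units; beyond the scatter), whereas the earlier comparison of these two amines changed the chain as well and stayed within the scatter. The step from the chain without an amine, an at least 4.2-fold lower number from compound 1 to compound 4 (0.63 log units; beyond the scatter), gives no exact size, since it starts from a limit: the limit of > 50000 nM in this assay, at which 1 of the 4 values shown sits.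

The compounds shown leave open whether a still longer or a shorter chain carrying dipentylamino would move the number beyond the scatter. They also leave open how a ring amine such as piperidine or morpholine at the chain end would compare with these open-chain amines.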